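The source may report more compounds than this note shows. Statements on the series, on what has been measured and on what is new or still open speak of the compounds shown alone.

Compound 1 `CC(C)NC(=O)N1CCN(C(=S)SCc2cn(Cc3ccccc3F)nn2)CC1` gives 7130 nM in a functional assay on SMMC-7721 cells (Homo sapiens) for cytotoxicity, read by MTT assay, with a stated time of 72 h; on this read-out higher numbers stand for weaker inhibition and lower numbers for stronger inhibition. Compound 2 `CCN(C)C(=O)N1CCN(C(=S)SCc2cn(Cc3ccccc3F)nn2)CC1`, which carries ethyl(methyl)amino in place of isopropylamino on a carbonyl carbon, gives 19700 nM in this assay, a step of a 2.8-fold higher number from compound 1 to compound 2 (0.44 log units; beyond the scatter). Compound 3 `Cc1ccc(Cn2cc(CSC(=S)N3CCN(C(=O)NC(C)C)CC3)nn2)cc1` carries 4-methylphenyl in place of 2-fluorophenyl on a saturated chain carbon bound to an aromatic nitrogen. In this assay compound 3 reaches only the limit > 128000 nM, which is a limit of the assay and not a number. This is the limit of > 128000 nM in this assay, at which 1 of the 3 values shown sits. The step is an at least 17-fold higher number from compound 1 to compound 3 (1.25 log units; beyond the scatter). Compound 4 `CCN(C)C(=O)N1CCN(C(=S)SCc2cn(Cc3ccc(C)cc3)nn2)CC1` differs from compound 3 by ethyl(methyl)amino in place of isopropylamino on a carbonyl carbon, the same change as ethyl(methyl)amino in place of isopropylamino on a carbonyl carbon at the same place, while the two cores differ by 4-methylphenyl in place of 2-fluorophenyl on a saturated chain carbon bound to an aromatic nitrogen. Because the same change produced a 2.8-fold higher number from compound 1 to compound 2 (0.44 log units; beyond the scatter) between compound 1 and compound 2, compound 4 is expected to move by about a step that the limit leaves unreadable from compound 3 to compound 4. The estimate for compound 4 is 300000 nM, expected between 120000 nM and 900000 nM.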

Compound 4, half-maximal inhibitory concentration: > 128000 nM
Compound 4: a limit, no number; the forecaster's own chance of this, stated with the estimate: 85%; the middle value is on the limit's open side.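

In this assay compound 4 gives > 128000 nM, a limit of the assay and not a number. Compound 3 sits at the same limit, so the step from isopropylamino to ethyl(methyl)amino cannot be read on the 4-methylphenyl core, and the data show neither that this change carries over to that core nor that it fails to. Replacing 2-fluorophenyl with 4-methylphenyl gives an at least 6.4-fold higher number from compound 2 to compound 4 (0.81 log units; beyond the scatter), and the comparison of this step with the earlier one reads: the same change on two cores in this assay, an at least 17-fold higher number (1.25 log units; beyond the scatter) from compound 1 to compound 3 and an at least 6.4-fold higher number (0.81 log units; beyond the scatter) from compound 2 to compound 4; the limit leaves it open whether they differ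

The compounds shown leave open whether an unsubstituted phenyl on the saturated chain carbon would stay measurable in this assay. They also leave open how dimethylamino on the carbonyl carbon would compare with isopropylamino.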